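The source may hold more compounds than are shown below. What is called first, only, known or untested is meant among the compounds shown, and "the series" means these compounds.

Among the measured compounds shown here, in a functional assay on HCT-116 cells (Homo sapiens) for antiproliferative activity, read by MTT assay, with a stated time of 72 h (a higher number here means a weaker inhibitor, a lower number a stronger inhibitor), compound 1 (`CC(C)NC(=N)NC(=N)Nc1ccc(C(F)(F)F)cc1`) gives 4800 nM, the lower of the two actual numbers so far. Compound 3 (`N=C(NC(=N)NC1CCCC1)Nc1ccc(F)cc1F`) gives 29500 nM. Compound 2 (`CC(C)NC(=N)NC(=N)Nc1ccc(F)cc1`) gives > 50000 nM, which is a limit of the assay and not a number.

For the measured compounds named here, the only measured single-place step is an at least 10-fold higher number from compound 1 to compound 2 (1.01 log units; beyond the scatter), with fluoro in place of trifluoromethyl on an aromatic carbon. That step is large, and it runs up against (the limit of > 50000 nM in this assay, at which 1 of the 3 values shown sits).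

Compound 4 (`CCN(C)C(=N)NC(=N)Nc1ccc(C(F)(F)F)cc1`) has the same atoms as compound 1, joined differently: ethyl(methyl)amino in place of isopropylamino on a carbon with a double bond to nitrogen. Going by the values given here, no measured step touches this place, so an at least 10-fold higher number from compound 1 to compound 2 (1.01 log units; beyond the scatter) offers only a weak guide and its size is not carried over.

In this assay, no step beyond the scatter is expected, with a slight lean towards a higher number. The expected change is a 1.7-fold higher number from compound 1 to compound 4 (0.22 log units; within the scatter). For compound 4 the estimated value is 8000 nM, with an expected range of 2500 nM to 25000 nM.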

Compound 4, half-maximal inhibitory concentration: 4000 nM
Compound 4: the middle estimate sits 2.0-fold (0.30 log units) above what was measured; low and high end bracket the measured number.
By their numbers in this assay, from the lowest: compounds 4 and 1 (each within the scatter of the next); then compound 3. At a limit, above all of these: compound 2.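

In this assay, among the compounds shown here, a 1.2-fold lower number from compound 1 to compound 4 (0.08 log units; within the scatter) is the first step at the carbon with a double bond to nitrogen, and it lies within the scatter. With the trifluoromethyl group kept, ethyl(methyl)amino therefore stands in for isopropylamino, with one hydrogen-bond donor fewer on the count, and no change beyond the scatter appears, unlike the large at least 10-fold higher number from compound 1 to compound 2 (1.01 log units; beyond the scatter) at the aromatic carbon. No measured property bears on this step, so its flat outcome has no stated cause.

Going by these compounds, how a longer chain such as hexylamino, or a morpholine ring, would fare at this place stays open. On these data alone, compound 2 gives > 50000 nM, which is a limit of the assay and not a number, and how the amine change behaves with fluoro on the aromatic carbon also stays open.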